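The compounds below may be only part of what the source reports. "The series", "measured", "known", "first", "only" and "open" are said of these compounds alone.

Three compounds share one core and differ only in the amine group on it. Compound 1 `CN(C)c1ccc2cc(NC(=O)CCc3ccc(C(F)(F)F)cc3)ccc2n1` carries dimethylamino, and in an assay on isolated protein for displacement of a labelled ligand from melanin-concentrating hormone receptor 1 (Homo sapiens) (a lower number here means a stronger inhibitor, a higher number a weaker inhibitor), compound 1 gives 13 nM. Compound 2 `O=C(CCc1ccc(C(F)(F)F)cc1)Nc1ccc2nc(N3CCCCCC3)ccc2c1` carries azepan-1-yl and gives 36 nM. Compound 3 `CCN(CC)c1ccc2cc(NC(=O)CCc3ccc(C(F)(F)F)cc3)ccc2n1` carries diethylamino and gives 88 nM, the highest number of the three, so compound 3 is the weakest binder among them. Each step between them is modest yet beyond the scatter: a 2.8-fold higher number from compound 1 to compound 2 (0.44 log units; beyond the scatter), a 6.8-fold higher number from compound 1 to compound 3 (0.83 log units; beyond the scatter) and a 2.4-fold higher number from compound 2 to compound 3 (0.39 log units; beyond the scatter).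

Compound 4 `CNC(=O)NC1CCN(c2ccc3cc(NC(=O)CCc4ccc(C(F)(F)F)cc4)ccc3n2)C1` has not been measured. It differs from compound 3 in one place: 3-((methylcarbamoyl)amino)pyrrolidin-1-yl in place of diethylamino on an aromatic carbon. For the measured compounds named here, no measured step swaps in a group of this kind, so the evidence is indirect. The steps show that several amines are accepted at this position within a narrow span, and that azepan-1-yl in compound 2, at 36 nM, sits between the two open-chain groups. The entering group likewise brings a ring, so the step is expected to run downward, roughly a 2.2-fold lower number from compound 3 to compound 4 (0.34 log units; beyond the scatter), though a change this large could also land anywhere across the span seen so far. Compound 4 is therefore estimated at about 40 nM, with a range from 10 nM to 160 nM.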

Compound 4, half-maximal inhibitory concentration: 6 nM
The estimate for compound 4 lay 6.7-fold (0.82 log units) above the measured number; the measured number lies below the stated range.
By their numbers in this assay, from the lowest: compound 4; then compound 1; then compound 2; then compound 3.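

For the compounds shown here, the position accepts much more than the simple amines of the earlier compounds suggested: in this assay, replacing diethylamino with 3-((methylcarbamoyl)amino)pyrrolidin-1-yl gives a 15-fold lower number from compound 3 to compound 4 (1.17 log units; beyond the scatter), and replacing azepan-1-yl with the same group gives a 6.0-fold lower number from compound 2 to compound 4 (0.78 log units; beyond the scatter). The new group also improves on dimethylamino, the best of the earlier amines, with a 2.2-fold lower number from compound 1 to compound 4 (0.34 log units; beyond the scatter), which makes compound 4 the strongest binder of the four. Among the earlier compounds, moving away from dimethylamino only raised the number, whereas compound 4 goes against that trend and shows that a group with a five-membered non-aromatic ring and hydrogen-bond donors, which diethylamino lacks, can reach a lower number here.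

Nothing presented here explains why this change lowers the number. The compounds shown also leave open which part of the new group matters, since plain pyrrolidin-1-yl, with no side group, or 3-aminopyrrolidin-1-yl would be needed to separate the contribution of the ring from that of the methylcarbamoyl part.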